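Methyl to Chloro on the Fused Core: Stability Outlook

A few compounds are considered here, and "the series" means these few. Any claim that something is new, unique, unknown or untested is made for them only; others in the source may bear on it.

Measured compounds:
Compound 1 `COc1cc(C2CCN(CC(N)=O)CC2)ccc1Nc1ncc2c(O)cc(-c3ccccc3N(C)S(C)(=O)=O)n2n1` gives a limit in an in vitro ADME assay on microsomes from liver (Homo sapiens) for metabolic stability, using NADPH, with a stated time of 10 min, tested at 0.5 uM; a lower number here means that the compound disappears faster, a higher number that the compound lasts longer: < 0.0834 h.
Compound 2 `COc1cc(C2CCN(CC(N)=O)CC2)ccc1Nc1ncc2c(C)cc(-c3ccccc3N(C)S(C)(=O)=O)n2n1` gives 0.3 h in this assay.

Compound 2 holds the only number shown in this assay; the other value is a limit. Going by the values given here, the one measured step, an at least 3.5-fold higher number from compound 1 to compound 2 (0.55 log units; beyond the scatter), is a methyl in place of a hydroxy on an aromatic carbon, and its lower end rests on a limit, as the limit of < 0.0834 h in this assay, at which 1 of the 2 values shown sits, records.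

Compound 3 `COc1cc(C2CCN(CC(N)=O)CC2)ccc1Nc1ncc2c(Cl)cc(-c3ccccc3N(C)S(C)(=O)=O)n2n1` differs from compound 2 by chloro in place of methyl on an aromatic carbon. No measured step bears on this exchange: the only step shown swapped hydroxy for methyl, not methyl for chloro, so it gives no guide to size or direction. Compound 3 is therefore expected to stay close to compound 2, at an estimated 0.4 h, within 0.15 h to 1 h. The step that this estimate means is a 1.3-fold higher number from compound 2 to compound 3 (0.12 log units; within the scatter), expected to lie within the scatter.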

Compound 3, half-life: 0.617 h
For compound 3 the middle estimate is 1.5-fold (0.19 log units) below the measured one; the measured number falls inside the stated range.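

Chloro in place of methyl gives a 2.1-fold higher number from compound 2 to compound 3 (0.31 log units; beyond the scatter), so in this assay this position on the five-membered aromatic ring responds even to an exchange of one heavy atom for one heavy atom, with no hydrogen-bond donor or acceptor on either side. Chloro in place of hydroxy gives an at least 7.3-fold higher number from compound 1 to compound 3 (0.86 log units; beyond the scatter), which puts the three groups at this position in the order hydroxy, methyl, chloro. Compound 1 holds a limit, so the steps from it have only a lower end: the limit of < 0.0834 h in this assay, at which 1 of the 3 values shown sits.

The compounds shown leave open where fluoro, bromo, a nitrile or a cyclopropyl group would fall in that order. They also leave open whether the step from methyl to chloro keeps its size when the 2-(methyl(methylsulfonyl)amino)phenyl group is changed.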